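The source may report more compounds than this note shows. Statements on the series, on what has been measured and on what is new or still open speak of the compounds shown alone.

Compound 3 `Fc1cc(Nc2cc(Nc3cccc(Cl)c3)ncn2)ccc1Oc1ccncc1-c1cccnc1` gives 690 nM in a functional assay on HT-29 cells (Homo sapiens) for cytotoxicity, read by MTT assay, with a stated time of 72 h (a higher number here means a weaker inhibitor, a lower number a stronger inhibitor), the lowest of the three numbers measured here. Compound 1 `COc1ccc(Nc2cc(Nc3ccc(Oc4ccncc4-c4cccnc4)c(F)c3)ncn2)cc1` gives 4110 nM in this assay, and compound 2 `Fc1ccc(Nc2cc(Nc3ccc(Oc4ccncc4-c4cccnc4)c(F)c3)ncn2)cc1F` gives 2320 nM. The group on a nitrogen on an aromatic ring is what sets these three apart: the step of a 6.0-fold lower number from compound 1 to compound 3 (0.77 log units; beyond the scatter) and the step of a 3.4-fold lower number from compound 2 to compound 3 (0.53 log units; beyond the scatter) both point the same way, towards compound 3, while the step of a 1.8-fold lower number from compound 1 to compound 2 (0.25 log units; within the scatter) is within the scatter. Compound 4 `Fc1ccc(Nc2cc(Nc3ccc(Oc4ccncc4-c4cccnc4)c(F)c3)ncn2)cc1` differs from compound 3 by 4-fluorophenyl in place of 3-chlorophenyl on a nitrogen on an aromatic ring. For the measured compounds named here, no measured step covers this exact exchange, but compound 2, which carries a 3,4-difluorophenyl there, sits well above compound 3, and compound 4 resembles compound 2 more than compound 3 in that group. Compound 4 is therefore expected to give a higher number than compound 3, a step of about a 2.6-fold higher number from compound 3 to compound 4 (0.42 log units; beyond the scatter), though smaller than the gap to compound 2. Compound 4 is estimated at 1800 nM, with a range from 700 nM to 4500 nM.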

Compound 4, half-maximal inhibitory concentration: 330 nM
For compound 4 the middle estimate is 5.5-fold (0.74 log units) above the measured one, and the stated range ends above it.
By their numbers in this assay, from the lowest: compound 4; then compound 3; then compounds 2 and 1 (each within the scatter of the next).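

In this assay the exchange of 3-chlorophenyl for 4-fluorophenyl on a nitrogen on an aromatic ring gives a 2.1-fold lower number from compound 3 to compound 4 (0.32 log units; beyond the scatter) and leaves compound 4 with the lowest number of the series. A single atom on that ring proves decisive: hydrogen in place of fluoro on an aromatic carbon gives a 7.0-fold lower number from compound 2 to compound 4 (0.85 log units; beyond the scatter) even though the two groups differ only there. Fluoro in place of methoxy gives a 12-fold lower number from compound 1 to compound 4 (1.10 log units; beyond the scatter) and is the largest step of the series, whereas compound 1 and compound 2 lie within the scatter of each other.

Nothing available here explains why these steps run as they do. As far as these compounds go, what a 4-chlorophenyl, or a phenyl carrying an amine or a carboxylic acid, would give on that nitrogen remains open.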